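A rearranged five-membered ring on a shared core

The source may hold more compounds than are shown below. What is called first, only, known or untested is meant among the compounds shown, and "the series" means these compounds.

Compound 3 `Cc1cc(C)c(CN2CCc3c(Cl)cc([C@H](CO)[C@@H]4CCCO4)c(Cl)c3C2=O)c(=O)[nH]1` is measured once in an assay for inhibition of histone-lysine N-methyltransferase EZH2 variant Y641N (Homo sapiens), read by scintillation counting, with a stated time of 60 min, in the presence of a further agent that is not named here (on this read-out higher numbers stand for weaker inhibition and lower numbers for stronger inhibition), where compound 3 gives 10 nM; two further entries for it carry no single number. The other compounds on the same core show wide spreads: in this assay compound 1 `COC(c1cc(Cl)c2c(c1Cl)C(=O)N(Cc1c(C)cc(C)[nH]c1=O)CC2)C1CCOC1` gives 130 nM; 30 nM; 1.9 nM; 0.6 nM (4 entries), and compound 2 `Cc1cc(C)c(CN2CCc3c(Cl)cc(C(CO)c4ccon4)c(Cl)c3C2=O)c(=O)[nH]1` gives 360 nM; 24 nM (2 entries), so that the repeated entries of compound 1 the several entries of compound 1 in this assay, 130 nM; 30 nM; 1.9 nM; 0.6 nM (4 entries) and of compound 2 the several entries of compound 2 in this assay, 360 nM; 24 nM (2 entries) stretch well beyond the usual scatter.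

Compound 4 `Cc1cc(C)c(CN2CCc3c(Cl)cc([C@@H](CO)[C@@H]4CCOC4)c(Cl)c3C2=O)c(=O)[nH]1` keeps the same atoms as compound 3, joined differently: a group of 8 heavy atoms (6 carbon, 2 oxygen; one five-membered non-aromatic ring with 1 hetero atom) in place of a group of 8 heavy atoms (6 carbon, 2 oxygen; one five-membered non-aromatic ring with 1 hetero atom), on an aromatic carbon. Among the compounds with values here, no measured pair isolates this change. Given the range seen for compound 1 130 nM; 30 nM; 1.9 nM; 0.6 nM (4 entries), the step from compound 3 to compound 4 in this assay is expected to be small, a 1.7-fold lower number from compound 3 to compound 4 (0.22 log units; within the scatter), and not clearly beyond the scatter. Compound 4 is therefore estimated at 6 nM, with a range from 0.8 nM to 45 nM.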

Compound 4, inhibition constant: 1260 nM
Estimate against measurement, compound 4: 210-fold (2.32 log units) below, outside the stated range (above it).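

In this assay, rejoining the same atoms gives a 130-fold higher number from compound 3 to compound 4 (2.10 log units; beyond the scatter), so at this aromatic carbon the way the group is joined matters, although the two groups match in every count, each with one five-membered non-aromatic ring with 1 hetero atom and 2 defined stereocentres. The earlier compounds shown here could not show this, as no measured pair among them differed in one place. Compound 3 and compound 4 each rest on a single number, however, and repeated entries on the shared core spread widely: the several entries of compound 1 in this assay, 130 nM; 30 nM; 1.9 nM; 0.6 nM (4 entries)

The two structures differ both in how the ring is attached and in their defined stereocentres, and the compounds shown do not separate these two changes. From the compounds shown here alone, whether a pyrrolidine, an amine with nitrogen in place of the ring oxygen, would track compound 3 or compound 4 remains open.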